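Triazole substituent swap on the butenolide series

The source may hold more compounds than are shown below. What is called first, only, known or untested is meant among the compounds shown, and "the series" means these compounds.

Among the measured compounds shown here, compound 1 `C[Si](C)(C)c1cn(C[C@H](O)[C@H]2OC(=O)C(OCc3ccccc3)=C2OCc2ccccc2)nn1` is the only member of the series with a numeric read-out. In a functional assay on HCT-116 cells (Homo sapiens) for antiproliferative activity, read by MTT assay, with a stated time of 72 h (on this read-out lower numbers stand for stronger inhibition and higher numbers for weaker inhibition), compound 1 gives 31800 nM. Compound 2 `CCCCCc1ccc(-c2cn(C/C=C3\OC(=O)C(OCc4ccccc4)=C3OCc3ccccc3)nn2)cc1` reaches only a limit of the assay, > 100000 nM. Compound 3 `O=C1O/C(=C\Cn2cc(-c3cc(C(F)(F)F)cc(C(F)(F)F)c3)nn2)C(OCc2ccccc2)=C1OCc1ccccc1` likewise returns a limit, > 100000 nM. For the measured compounds named here, the series as a whole sits near (the limit of > 100000 nM in this assay, at which 2 of the 3 values shown sit), so compound 1 stands as the one resolved value, at the weak end of what the assay resolves.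

Compound 4 `O=C1O[C@H]([C@@H](O)Cn2cc(-c3ccc(Br)cc3)nn2)C(OCc2ccccc2)=C1OCc1ccccc1` differs from compound 1 by a group of 7 heavy atoms (6 carbon, 1 bromine; one six-membered aromatic ring of carbon only) in place of a group of 4 heavy atoms (3 carbon, 1 silicon; no ring), on an aromatic carbon. Going by the values given here, no measured pair isolates this change, and compound 2 and compound 3 differ from compound 1 in more than one place. A step in this assay no larger than the scatter, or a modest loss, is expected. Compound 4 is estimated at 45000 nM, between 12000 nM and 150000 nM, the expected step being a 1.4-fold higher number from compound 1 to compound 4 (0.15 log units; within the scatter).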

Compound 4, half-maximal inhibitory concentration: 9420 nM
Beside the measured number, compound 4's estimate is 4.8-fold (0.68 log units) above it; measured number below the stated range.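

At this aromatic carbon, 4-bromophenyl in place of the group of 3 carbon and 1 silicon gives a 3.4-fold lower number from compound 1 to compound 4 (0.53 log units; beyond the scatter) in this assay, so the position accepts an aromatic ring without loss. Steps to compound 2 and compound 3 cannot be read, as each differs from compound 4 in more than one place. Compound 4 adds a second resolved value, clear of the limit: the limit of > 100000 nM in this assay, at which 2 of the 4 values shown sit.

From the compounds shown here alone, whether the gain belongs to the ring or to the bromine stays open. So does the effect of an unsubstituted phenyl, or of an amine on that ring.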